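A neopentyl group in place of 3-methylphenyl

The source may report more compounds than this note shows. Statements on the series, on what has been measured and on what is new or still open speak of the compounds shown alone.

In a functional assay on a cell-free system (plasma, Homo sapiens), with a stated time of 3 min (on this read-out higher numbers stand for weaker inhibition and lower numbers for stronger inhibition), compound 1 (`Cc1cccc([C@@H](O)C(=O)N2N=CC[C@H]2C(=O)NCc2cc(Cl)ccc2-n2cnnn2)c1`) gives 830 nM. Compound 2 (`CC(C)(C)OC[C@@H](O)C(=O)N1[C@H](C(=O)NCc2cc(Cl)ccc2-n2cnnn2)C[C@@H]2C[C@@H]21`) gives 500 nM, within the scatter of compound 1. Compound 3 (`O=C(NCc1cc(Cl)ccc1-n1cnnn1)[C@@H]1[C@@H]2C[C@@H]2CN1C(=O)[C@H](O)Cc1ccccn1`) gives 1700 nM, a number higher than that of compound 1 by a step just beyond the scatter.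

Compound 4 (`CC(C)(C)C[C@@H](O)C(=O)N1N=CC[C@H]1C(=O)NCc1cc(Cl)ccc1-n1cnnn1`) keeps the core of compound 1 and carries neopentyl in place of 3-methylphenyl on a saturated chain carbon bound to a carbonyl carbon and an oxygen on a saturated carbon. Within the data shown here, no measured pair isolates this change. Compound 2, on a different core, reaches 500 nM with no aromatic ring on that chain. In this assay the expected step of a 1.2-fold lower number from compound 1 to compound 4 (0.07 log units; within the scatter) stays within the scatter. The estimate for compound 4 is 700 nM, with an expected range from 220 nM to 2300 nM.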

Compound 4, half-maximal inhibitory concentration: 590 nM
The estimate for compound 4 lay 1.2-fold (0.07 log units) above the measured number, and the stated range covers the measured number.
By their numbers in this assay, from the lowest: compounds 2, 4 and 1 (each within the scatter of the next); then compound 3.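

In this assay, neopentyl in place of 3-methylphenyl gives a 1.4-fold lower number from compound 1 to compound 4 (0.15 log units; within the scatter) and so shows that, on the core of compound 1, this saturated chain carbon can carry a group with no ring and fewer heavy atoms without a step beyond the scatter. Before this, only compound 2, on a different core, had shown a chain without an aromatic ring there. Nothing shown here explains why these two groups read alike.

Going by these compounds, it remains open how an amine or a carboxylic acid would read in this place on the core of compound 1, and the same holds for a longer chain.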